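The source may hold more compounds than are shown below. What is called first, only, known or untested is meant among the compounds shown, and "the series" means these compounds.

Measured so far in an assay for inhibition of Polyunsaturated fatty acid 5-lipoxygenase (Rattus norvegicus); a lower number here means a stronger inhibitor, a higher number a weaker inhibitor:

compound 1, `Oc1cc2c(cc1CCCOc1ccccc1)OC(CCc1ccccc1)C2`: 23 nM
compound 2, `Oc1cc2c(cc1CCCSc1ccncc1)OC(CCc1ccccc1)C2`: 8 nM

Compound 2 holds the lowest of the two numbers in this assay. Going by the values given here, the single measured step, a 2.9-fold lower number from compound 1 to compound 2 (0.46 log units; beyond the scatter), separates it from compound 1, and that step changes both the linking atom and the aromatic ring at the end of the three-carbon chain.

Compound 3, `Oc1cc2c(cc1CCCSc1nc3ccccc3s1)OC(CCc1ccccc1)C2`, is not yet measured in this assay. It differs from compound 2 in one place: 1,3-benzothiazol-2-yl in place of pyridin-4-yl on a sulfur. The sulfur link of compound 2 is kept; only the aromatic group on it is exchanged. Among the compounds with values here, no measured step bears on this exchange. Within the data shown here, the one step seen, a 2.9-fold lower number from compound 1 to compound 2 (0.46 log units; beyond the scatter), changes the sulfur and the ring together, so it cannot be split into a part for the sulfur and a part for the ring, and it gives no direction for the entering group. With the sulfur link retained, the number is expected to stay close to that of compound 2, within or only modestly beyond the scatter, in no preferred direction.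

Compound 3 is therefore estimated at 8 nM, with a range from 2.5 nM to 25 nM. The expected step is no change at the digits printed from compound 2 to compound 3 (within the scatter).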

Compound 3, half-maximal inhibitory concentration: 45 nM
Beside the measured number, compound 3's estimate is 5.6-fold (0.75 log units) below it, and the stated range ends below it.
By their numbers in this assay, from the lowest: compound 2; then compounds 1 and 3 (each within the scatter of the next).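

With the sulfur link held constant, this assay still responds to the aromatic group on the sulfur: exchanging pyridin-4-yl for 1,3-benzothiazol-2-yl gives a 5.6-fold higher number from compound 2 to compound 3 (0.75 log units; beyond the scatter) and so separates the two sulfur-linked compounds beyond the scatter, something the earlier step could not show because it changed the linking atom and the ring together. The other new comparison reads a 2.0-fold higher number from compound 1 to compound 3 (0.29 log units; within the scatter) and shows that a sulfur-linked compound is not set apart from compound 1 by the sulfur link alone, since this exchange replaces the link and the terminal aromatic group at once and stays within the scatter. No supporting data are available to account for the response to the group on the sulfur.

Going by these compounds, how much of the original step belongs to the sulfur and how much to pyridin-4-yl remains open, and a phenyl group on the sulfur or a pyridin-4-yl group on an oxygen would separate the two contributions. Also open, on these data alone, is whether the same response to the group on the sulfur would hold with a longer chain or with an amine on the terminal aromatic ring.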